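Swapping a Methyl-Bearing Ring for a Fluorine-Bearing One

The source may hold more compounds than are shown below. What is called first, only, known or untested is meant among the compounds shown, and "the series" means these compounds.

Compound 3 `COc1cc2ncnc(NCc3cccc(NC(=O)Nc4cccc(C)c4)c3)c2cc1OC` is a urea whose outer ring carries a methyl group. In a functional assay on HepG2 cells (Homo sapiens) for antiproliferative activity, read by MTT assay (a higher number here means a weaker inhibitor, a lower number a stronger inhibitor), compound 3 gives 21500 nM. Two related ureas, built on a shared core that lacks the methoxy groups of compound 3, give numbers close to it: compound 1 `COc1ccccc1NC(=O)Nc1cccc(CNc2ncnc3ccccc23)c1` gives 17500 nM and compound 2 `CC(C)(C)c1ccc(NC(=O)Nc2cccc(CNc3ncnc4ccccc34)c2)cc1` gives 17000 nM. All three numbers lie within the usual scatter of one another, so none of the three can be told apart from the others on these data.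

Compound 4 `COc1cc2ncnc(NCc3cccc(NC(=O)Nc4ccccc4F)c3)c2cc1OC` differs from compound 3 in one place: 2-fluorophenyl in place of 3-methylphenyl on an amide-type nitrogen. Within the data shown here, the only measured step that exchanges the ring on this same amide-type nitrogen is a 1.0-fold lower number from compound 1 to compound 2 (0.01 log units; within the scatter), and it left the number essentially where it was. Among the measured compounds shown here, no measured compound yet carries a fluorine on that ring, so the expectation rests on that single comparison and on the narrow spread of the three numbers. For compound 4 the expected step is a 1.1-fold lower number from compound 3 to compound 4 (0.03 log units; within the scatter), that is, no change beyond the scatter. Compound 4 is therefore estimated to give 20000 nM in this assay, with a likely range from 8000 nM to 50000 nM.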

Compound 4, half-maximal inhibitory concentration: 24900 nM
Compound 4: middle estimate off by 1.2-fold (0.10 log units), on the low side, within the range that was stated.
By their numbers in this assay, from the lowest: compounds 2, 1, 3 and 4 (each within the scatter of the next).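

In this assay, the new step is a 1.2-fold higher number from compound 3 to compound 4 (0.06 log units; within the scatter), so on the core of compound 3 a ring bearing fluorine and a ring bearing methyl on this amide-type nitrogen cannot be told apart. Among these compounds, until now, the only reading of a ring exchange at this place came from a 1.0-fold lower number from compound 1 to compound 2 (0.01 log units; within the scatter), on the core without the methoxy groups; there are now two such exchanges, one on each core, and both stay within the scatter. No measurement of any kind is available that would explain why this position gives such similar numbers across these four different rings.

Going by these compounds, whether this flat picture holds for groups of a different kind remains open, for instance an amine or a carboxylic acid on the outer ring, or a longer chain in place of that ring. On these data alone, what the methoxy groups of the core contribute also stays open: every pair of compounds across the two cores differs on the outer ring as well, so their effect cannot be separated from that of the ring.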